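The compounds below may be only part of what the source reports. "The series", "measured", "known", "first", "only" and "open" are said of these compounds alone.

Compound 3, `Cc1cc(N2CCCC2)cn2c(CSCCc3ccccc3)cnc12`, is the compound followed here. In an ADME assay on HEL cells (Homo sapiens) for cytotoxicity, with a stated time of 3 days (a lower number here means that less compound is tolerated, a higher number that more compound is tolerated), compound 3 gives 20 ug/mL, level with compound 1, `C=Cc1ccc(-c2cc(C)c3ncc(CSCCc4ccccc4)n3c2)cc1`, which gives 20 ug/mL in this assay; together these two are the highest of the three numbers. Compound 2, `Cc1cc(-c2ccsc2)cn2c(CSCc3ccccc3)cnc12`, gives 4 ug/mL in this assay, the lowest of the three, but compound 2 differs from compound 3 in more than one place, so its two values show only that gap and nothing about any single change.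

Compound 4 is `Cc1cc(-n2cccc2)cn2c(CSCCc3ccccc3)cnc12`. It differs from compound 3 in one place: 1H-pyrrol-1-yl in place of pyrrolidin-1-yl on an aromatic carbon. Going by the values given here, no measured step covers this exact change. Among the compounds with values here, the one measured step at the same place is no change at the digits printed from compound 1 to compound 3 (within the scatter), which showed no change beyond the scatter when a very different group was put there. On that basis a step of about no change at the digits printed from compound 3 to compound 4 (within the scatter) is expected, none beyond the scatter, in this assay. Compound 4 is therefore estimated at 20 ug/mL, within a range from 5 ug/mL to 50 ug/mL.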

Compound 4, minimum cytotoxic concentration: >= 4 ug/mL
Compound 4 gave a limit, no number; the forecaster's own chance of this, stated with the estimate: 10%; the middle value is on the limit's open side.
By their numbers in this assay, from the lowest: compound 2; then compounds 1 and 3 (each within the scatter of the next).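

Going by these compounds alone, no step from compound 3 or compound 1 to compound 4 can be read, because compound 4 gave a limit and not a number: the limit of >= 4 ug/mL in this assay, at which 1 of the 4 values shown sits. The compounds shown leave open whether 1H-pyrrol-1-yl in place of pyrrolidin-1-yl changes the number in this assay at all.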